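A few compounds are considered here, and "the series" means these few. Any claim that something is new, unique, unknown or untested is made for them only; others in the source may bear on it.

In an in vitro functional assay on HEK285-7 cells for antagonist activity at prostaglandin D2 receptor 2 (Homo sapiens), read by BRET and beta-arrestin recruitment (on this read-out higher numbers stand for weaker inhibition and lower numbers for stronger inhibition), compound 1 `O=C(O)Cc1sc(C2COc3ccccc3O2)nc1-c1ccc(Cl)cc1` gives 2000 nM and compound 2 `O=C(O)Cc1sc(C(c2ccc(F)cc2)c2ccc(F)cc2)nc1-c1ccc(Cl)cc1` gives 180 nM. Compound 3 `CS(=O)(=O)Nc1cccc(-c2nc(C(c3ccc(F)cc3)c3ccc(F)cc3)sc2CC(=O)O)c1` gives 370 nM, the second highest of the three numbers, nearer to compound 2 than to compound 1. Going by the values given here, the only single-point step measured so far is a 2.1-fold higher number from compound 2 to compound 3 (0.31 log units; beyond the scatter). Compound 4 `COc1cc(-c2nc(C(c3ccc(F)cc3)c3ccc(F)cc3)sc2CC(=O)O)ccn1` differs from compound 3 by 2-methoxypyridin-4-yl in place of 3-(methanesulfonamido)phenyl on an aromatic carbon. That measured step bears on this change only loosely: it also exchanged one aryl group for another at the same place and moved the number modestly, so a modest step cannot be ruled out, but none beyond the scatter is firmly indicated. Compound 4 is expected at 300 nM, with a range from 120 nM to 750 nM. The expected step is a 1.2-fold lower number from compound 3 to compound 4 (0.09 log units; within the scatter).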

Compound 4, half-maximal inhibitory concentration: 380 nM
Compound 4: middle estimate off by 1.3-fold (0.10 log units), on the low side, within the range that was stated.
By their numbers in this assay, from the lowest: compound 2; then compounds 3 and 4 (each within the scatter of the next); then compound 1.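

In this assay, putting 2-methoxypyridin-4-yl in place of 3-(methanesulfonamido)phenyl on this aromatic carbon gives a 1.0-fold higher number from compound 3 to compound 4 (0.01 log units; within the scatter), so the two groups are not told apart here, although only the group leaving carries a hydrogen-bond donor. Measured against 4-chlorophenyl, 2-methoxypyridin-4-yl gives a 2.1-fold higher number from compound 2 to compound 4 (0.32 log units; beyond the scatter), which places a second, different group on the weaker side of 4-chlorophenyl. No supporting evidence accounts for either step. Still open, going by these compounds, is how an amine or a carboxylic acid in place of the methoxy group on the pyridine would read. Also open, on these data alone, is whether a longer alkoxy chain there would separate from compound 4.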